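The source may report more compounds than this note shows. Statements on the series, on what has been measured and on what is new or still open speak of the compounds shown alone.

Measured compounds:
compound 1 `CC(C)n1nc(-c2cc(-c3ccccc3)on2)c2c(N)ncnc21`, 190 nM
compound 2 `Nc1ncnc2c1c(-c1cc(C3CC3)on1)nn2C1CCOCC1`, 5 nM

In an assay on isolated protein for inhibition of proto-oncogene tyrosine-protein kinase receptor Ret (Homo sapiens), read by radiometric assay and 33P incorporation, in the presence of a further agent that is not named here (on this read-out higher numbers stand for weaker inhibition and lower numbers for stronger inhibition), compound 1 gives 190 nM and stands at the higher of the two numbers, while compound 2 gives 5 nM, a gap beyond the scatter. Compound 3 `CC(C)n1nc(-c2ccon2)c2c(N)ncnc21` shares the core of compound 1 and differs from it in one place: hydrogen in place of phenyl on an aromatic carbon. For the measured compounds named here, with no measured pair showing this change, the expected step is a loss of inhibition, as an estimate, a 7.9-fold higher number from compound 1 to compound 3 (0.90 log units; beyond the scatter), beyond the scatter, because only compound 1 at 190 nM anchors the series here. Compound 3 is therefore expected at 1500 nM, within 400 nM to 6000 nM.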

Compound 3, half-maximal inhibitory concentration: 213 nM
Estimate against measurement, compound 3: 7.0-fold (0.85 log units) above, and the stated range ends above it.
By their numbers in this assay, from the lowest: compound 2; then compounds 1 and 3 (each within the scatter of the next).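

Hydrogen in place of phenyl on the aromatic carbon next to the ring oxygen leaves inhibition in this assay unchanged within the scatter (a 1.1-fold higher number from compound 1 to compound 3 (0.05 log units; within the scatter)). With the core of compound 1 held fixed, this position therefore tolerates the loss of the whole phenyl, at least in this one pair. No available evidence accounts for this result.

From the compounds shown here alone, only phenyl and hydrogen can be compared directly at this carbon, so it remains open whether an amine or a carboxylic acid there would also leave inhibition unchanged. Compound 2 differs from compound 3 in more than one place, so it cannot settle this.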